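A few compounds are considered here, and "the series" means these few. Any claim that something is new, unique, unknown or untested is made for them only; others in the source may bear on it.

Measured in a functional assay on DU-145 cells (Homo sapiens) for cytotoxicity, read by MTT assay, with a stated time of 2 days, tested at 10 uM; on this read-out higher numbers stand for more inhibition at the one concentration tested (going by the name of the read-out) and lower numbers for less inhibition:

compound 1, `Cc1cccc(N2CCN(CCCNc3nc(NCc4ccco4)c4ccccc4n3)CC2)c1C`: 91.5%
compound 2, `Fc1ccc2nc(NCCCCN3CCN(c4cccc(Cl)c4Cl)CC3)nc(NCc3ccco3)c2c1`: 95.5%
compound 3, `Clc1cccc(N2CCN(CCCNc3nc(NCc4ccco4)c4ccccc4n3)CC2)c1Cl`: 93.2%

All three compounds share a furan-bearing core with a chain that ends in a ring holding two nitrogens, and one of those nitrogens carries an aromatic ring. Compound 3 and compound 1 differ in one place only: 2,3-dimethylphenyl in place of 2,3-dichlorophenyl on an amine nitrogen in a ring. This exchange gives a number 1.7 percentage points lower from compound 3 to compound 1 (within the scatter), a step that does not stand out from the scatter of repeated measurements.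

Compound 2 carries a different core from compound 3; the difference between the two cores is not broken down here. Its value sits close to those of compound 3 and compound 1, and nothing in the numbers separates the three from one another.

Compound 4, `Cc1cccc(N2CCN(CCCCNc3nc(NCc4ccco4)c4cc(F)ccc4n3)CC2)c1C`, has not been measured in this assay. Set against compound 2, it shows one change, (2,3-dimethylphenyl in place of 2,3-dichlorophenyl on an amine nitrogen in a ring), at a place described in the same words as for the pair compound 3 and compound 1, so it is the same change on a different core. Within the data shown here, the only guide to its size is the measured pair, and that gives a step within the scatter. The step from compound 2 to compound 4 is therefore expected to be small, a number 2 percentage points lower from compound 2 to compound 4 (within the scatter), because a number 1.7 percentage points lower from compound 3 to compound 1 (within the scatter) was small on the other core. Compound 4 is thus estimated at 93.5%, with a likely range from 86% to 99%.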

Compound 4, a percentage reported as inhibition, at one concentration (the size of the read-out at that concentration, not a potency): 93.4%
Compound 4: middle estimate off by 0.1 percentage points, on the high side, and the stated range covers the measured number.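

In this assay, placing 2,3-dimethylphenyl where 2,3-dichlorophenyl stood on the core of compound 2 gives a number 2.1 percentage points lower from compound 2 to compound 4 (within the scatter), so the exchange leaves no visible mark on this core. The exchange therefore reads the same on both cores, and within this small set its outcome on one core was a fair guide to its outcome on the other: the same change on two cores in this assay, a number 1.7 percentage points lower (within the scatter) from compound 3 to compound 1 and a number 2.1 percentage points lower (within the scatter) from compound 2 to compound 4, 0.4 percentage points apart, within the scatter of two such steps. Among these compounds, this does not show that the two groups are truly equal or that the match would hold on any further core, since it rests on only two pairs, each with a step that cannot be told from scatter, and all four numbers sit near the top of a percentage scale, where a single concentration may hide real differences in potency.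

The compounds shown leave open whether a plain phenyl, or a phenyl carrying a methoxy or trifluoromethyl group, would give a step beyond the scatter on either core, and whether the same holds when the furan is exchanged for another ring. They also leave open how compounds this close would rank at lower concentrations, where their numbers would no longer crowd the top of the scale.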